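The source may report more compounds than this note shows. Statements on the series, on what has been measured and on what is new or still open speak of the compounds shown alone.

The measured compounds:
compound 1, `CC(C)=CC[C@@H](OC[C@H](C)O)C1=CC(=O)c2c(O)ccc(O)c2C1=O`: 24500 nM
compound 2, `COC(C)CO[C@H](CC=C(C)C)C1=CC(=O)c2c(O)ccc(O)c2C1=O`: 16600 nM
compound 3, `CCCCC(CC(=O)O[C@H](CC=C(C)C)C1=CC(=O)c2c(O)ccc(O)c2C1=O)OC(C)=O`: 67700 nM

In a functional assay on DU-145 cells (Homo sapiens) for cytotoxicity, read by MTT assay (a lower number here means a stronger inhibitor, a higher number a weaker inhibitor), compound 3 gives the highest of the three numbers, and both compound 1 and compound 2 give lower numbers beyond the scatter. Compound 4, `CC[C@@](C)(O)CC(=O)O[C@H](CC=C(C)C)C1=CC(=O)c2c(O)ccc(O)c2C1=O`, differs from compound 3 in one place: 1-hydroxy-1-methylpropyl in place of 1-acetoxypentyl on a saturated chain carbon bound to a carbonyl carbon. For the measured compounds named here, the only measured step, a 1.5-fold lower number from compound 1 to compound 2 (0.17 log units; within the scatter), sits on a saturated chain carbon bound to an oxygen on a saturated carbon, not on a saturated chain carbon bound to a carbonyl carbon, and was within the scatter, so it does not bear on this change. Going by the values given here, no measured pair shows what 1-hydroxy-1-methylpropyl in place of 1-acetoxypentyl does. The estimate for compound 4 in this assay is therefore 45000 nM, with a range of 15000 nM to 130000 nM. The expected step is a 1.5-fold lower number from compound 3 to compound 4 (0.18 log units; within the scatter), in no firm direction.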

Compound 4, half-maximal inhibitory concentration: 12700 nM
Estimate against measurement, compound 4: 3.5-fold (0.55 log units) above, outside the stated range (below it).
By their numbers in this assay, from the lowest: compounds 4, 2 and 1 (each within the scatter of the next); then compound 3.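

In this assay, the place on a saturated chain carbon bound to a carbonyl carbon proved sensitive to its group: 1-hydroxy-1-methylpropyl in place of 1-acetoxypentyl gave a step beyond the scatter (a 5.3-fold lower number from compound 3 to compound 4 (0.73 log units; beyond the scatter)). Compound 4 could not be separated from the compounds carrying 2-methoxypropyl (a 1.3-fold lower number from compound 2 to compound 4 (0.12 log units; within the scatter)) or 2-hydroxypropyl (a 1.9-fold lower number from compound 1 to compound 4 (0.29 log units; within the scatter)), as both steps lie within the scatter. No evidence explains the step to compound 4. The change alters chain and oxygen substituent together, so neither can be credited alone. From the compounds shown here alone, what an amine or a carboxylic acid would do at this place remains open.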